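Moving from 3,5-dichlorophenyl to 3-chloro-4-hydroxyphenyl

The compounds below may be only part of what the source reports. "The series", "measured", "known", "first", "only" and "open" are said of these compounds alone.

Compound 1 `COc1ccc(/C=C2\CCC/C(=C\c3ccccc3Cl)C2=O)cc1OC`: 7100 nM
Compound 2 `COc1ccc(/C=C2\CCC/C(=C\c3ccc(Cl)cc3Cl)C2=O)cc1OC`: 10300 nM
Compound 3 `COc1ccc(/C=C2\CCC/C(=C\c3cc(Cl)cc(Cl)c3)C2=O)cc1OC`: 2500 nM

In a functional assay on SW-620 cells (Homo sapiens) for cytotoxicity, read by MTT assay, with a stated time of 72 h (a higher number here means a weaker inhibitor, a lower number a stronger inhibitor), compound 3 gives the lowest of the three numbers, 2500 nM. Compound 4 `COc1ccc(/C=C2\CCC/C(=C\c3ccc(O)c(Cl)c3)C2=O)cc1OC` carries 3-chloro-4-hydroxyphenyl in place of 3,5-dichlorophenyl on a double-bonded chain carbon bound to a double-bonded ring carbon. Two measured steps change the group at this place: a 2.8-fold lower number from compound 1 to compound 3 (0.45 log units; beyond the scatter) and a 4.1-fold lower number from compound 2 to compound 3 (0.61 log units; beyond the scatter). Both are modest, while a 1.5-fold higher number from compound 1 to compound 2 (0.16 log units; within the scatter) stays within the scatter. For the measured compounds named here, no measured compound carries a hydroxy group, so the guidance is indirect. Since the other two compounds sit higher, a modest move to a higher number is expected, an estimated 2.2-fold higher number from compound 3 to compound 4 (0.34 log units; beyond the scatter). The estimate for compound 4 is 5500 nM, with an expected range of 2000 nM to 15000 nM.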

Compound 4, half-maximal inhibitory concentration: 7100 nM
Beside the measured number, compound 4's estimate is 1.3-fold (0.11 log units) below it, within the range that was stated.
By their numbers in this assay, from the lowest: compound 3; then compounds 1, 4 and 2 (each within the scatter of the next).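

In this assay, a hydroxy group now appears at this place, and the lower number of 3,5-dichlorophenyl is not kept (a 2.8-fold higher number from compound 3 to compound 4 (0.45 log units; beyond the scatter)). Against the other two groups, 3-chloro-4-hydroxyphenyl stays within the scatter (a 1.5-fold lower number from compound 2 to compound 4 (0.16 log units; within the scatter); no change at the digits printed from compound 1 to compound 4 (within the scatter)), so among these four compounds only compound 3 stands apart. No information is available that explains this difference. From the compounds shown here alone, this step changes the chlorine pattern and adds the hydroxy group together, so the share of each remains open. Also open, going by these compounds, is whether an amine in place of the hydroxy group would match compound 3 or compound 4.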